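Cycloheptyl in Place of an Aryl Group at the Ring Amine

A few compounds are considered here, and "the series" means these few. Any claim that something is new, unique, unknown or untested is made for them only; others in the source may bear on it.

Measured compounds:
compound 1 `Nc1scc(CN2CCN(c3ccc(F)cc3Cl)CC2)c1C(=O)c1ccc(Cl)cc1` gives 0%
compound 2 `COc1ccc(N2CCN(Cc3csc(N)c3C(=O)c3ccc(Cl)cc3)CC2)cc1` gives 0%
compound 3 `Nc1scc(CN2CCN(c3c(F)cccc3F)CC2)c1C(=O)c1cccc(C(F)(F)F)c1` gives 0%

In an assay on CHO cells for displacement of a labelled ligand from adenosine receptor A3 (Homo sapiens), read by scintillation counting, with a stated time of 120 min, tested at 10 uM (a higher number here means more inhibition at the concentration tested (going by the name of the read-out), a lower number less inhibition), compound 1 stands level with compound 2 and compound 3 at the digits shown. For the measured compounds named here, the single measured step within this set, no change at the digits printed from compound 1 to compound 2 (within the scatter), moved nothing beyond the scatter. Compound 4 `Nc1scc(CN2CCN(C3CCCCCC3)CC2)c1C(=O)c1ccc(Cl)cc1` differs from compound 1 by cycloheptyl in place of 2-chloro-4-fluorophenyl on an amine nitrogen in a ring. Going by the values given here, no measured step exchanges an aromatic group for a non-aromatic ring on this nitrogen, so the only guide is the step already seen, which was flat. Compound 4 is therefore expected to show a number 5 percentage points higher from compound 1 to compound 4 (within the scatter), that is, no change beyond the scatter. The estimated value for compound 4 is 5%, with a range from 0% to 25%.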

Compound 4, a percentage reported as inhibition, at one concentration (the size of the read-out at that concentration, not a potency): 0%
Beside the measured number, compound 4's estimate is 5 percentage points above it; the measured number falls inside the stated range.
By their numbers in this assay, from the lowest: compounds 1, 2, 3 and 4 (each within the scatter of the next).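

In this assay, putting a non-aromatic ring on this amine nitrogen in place of an aryl group gives no change at the digits printed from compound 1 to compound 4 (within the scatter), and likewise no change at the digits printed from compound 2 to compound 4 (within the scatter). The flat reading at this position therefore extends from 2-chloro-4-fluorophenyl and 4-methoxyphenyl to cycloheptyl, a seven-membered ring of carbon only. No supporting evidence bears on this result. As far as these compounds go, it remains open whether a longer chain or a group carrying a carboxylic acid on this nitrogen would read differently from compound 4 at 0%.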